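Amide substituent variation on a shared core series

This account rests on a few compounds, and the source may have more. Where it says the series, first, only, none or still open, it means among the compounds named here.

Measured so far:
compound 1 `Cc1cccc(Cn2c(CN3CCN(C(=O)C4CCCC4)CC3)nc3ccccc32)c1` — 67.5%
compound 2 `COc1cccc(Cn2c(CN3CCN(C(=O)C4CC4)CC3)nc3ccccc32)c1` — 44.4%

In an assay on isolated protein for inhibition of aldehyde dehydrogenase 1A1 (Homo sapiens), read by spectrophotometry, tested at 10 uM (on this read-out higher numbers stand for more inhibition at the one concentration tested (going by the name of the read-out) and lower numbers for less inhibition), compound 1 gives 67.5%, the higher of the two numbers. Compound 2 gives 44.4% in this assay, a value that lies beyond the scatter below that of compound 1. Going by the values given here, compound 1 and compound 2 differ in two places at once, so no single step between them can be read; the pair shows only that their two values differ.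

Compound 3 `Cc1cccc(Cn2c(CN3CCN(C(=O)c4ccc(F)cc4)CC3)nc3ccccc32)c1` has not yet been measured. It differs from compound 1 by 4-fluorophenyl in place of cyclopentyl on a carbonyl carbon; cut one bond further out, the change reads cyclopentylcarbonyl to (4-fluorophenyl)carbonyl. Among the compounds with values here, no measured pair in this set carries a change of this kind at the carbonyl carbon, so no step size can be taken from the data, and compound 1 is the only anchor.

The step from compound 1 to compound 3 is expected to be small, most likely a modest drop within or just beyond the scatter, a number 9.5 percentage points lower from compound 1 to compound 3 (within the scatter). Compound 3 is estimated at 58% in this assay, with a range from 33% to 83%.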

Compound 3, a percentage reported as inhibition, at one concentration (the size of the read-out at that concentration, not a potency): 27.1%
For compound 3 the middle estimate is 30.9 percentage points above the measured one; measured number below the stated range.
By their numbers in this assay, from the lowest: compound 3; then compound 2; then compound 1.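

In this assay, going by these compounds alone, the swap to 4-fluorophenyl in place of cyclopentyl on a carbonyl carbon gives a number 40.4 percentage points lower from compound 1 to compound 3 (beyond the scatter) and so provides the first readable step, marking the group on this carbonyl carbon as one that strongly changes the read-out. Cyclopentyl is compatible with the higher inhibition on the core of compound 1, while 4-fluorophenyl is not, although this single change replaces a non-aromatic five-membered ring with an aromatic six-membered ring and adds fluorine all at once. Nothing available here accounts for the fall in inhibition.

Still open, going by these compounds, is whether the aromatic ring or the fluorine goes with the loss, a question that an unsubstituted phenyl or a cyclohexyl on the same carbonyl carbon would help to separate. Steps involving compound 2 cannot be read, since it differs from compound 1 and from compound 3 in more than one place, which leaves the separate contributions of its methoxy and cyclopropyl groups unresolved.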